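The compounds below may be only part of what the source reports. "The series", "measured", "known", "first", "only" and "open" are said of these compounds alone.

Measured compounds:
compound 1 `C=CC(=O)Nc1cccc(Nc2ncnc3ccc(-c4ccc(Cl)nc4)cc23)c1` — a functional assay on Ramos cells (Homo sapiens) for inhibition, read by MTT assay, with a stated time of 48 h; a higher number here means a weaker inhibitor, a lower number a stronger inhibitor "not determined" (no result reported)
compound 2 `C=CC(=O)Nc1cccc(Oc2ncnc3ccc(-c4ccc(F)nc4)cc23)c1` — this assay 11000 nM
compound 3 `C=CC(=O)Nc1cccc(Oc2ncnc3ccc(-c4ccc(Cl)nc4)cc23)c1` — this assay 10100 nM

Going by the values given here, compound 3 holds the lowest of the two numbers, but the single step of a 1.1-fold lower number from compound 2 to compound 3 (0.04 log units; within the scatter) is within the scatter, so compounds 2 and 3 are not separated. Compound 4 `C=CC(=O)Nc1cccc(Oc2ncnc3ccc(-c4cnc5ccccc5c4)cc23)c1` differs from compound 3 by quinolin-3-yl in place of 6-chloropyridin-3-yl on an aromatic carbon. Among the compounds with values here, no measured step touches this kind of change: the one known step swaps only a halogen on the same ring, and compound 1 gives nothing to compare. The expectation therefore rests on the two numbers close together, and a step of a 1.3-fold lower number from compound 3 to compound 4 (0.10 log units; within the scatter) no larger than the scatter is expected, with a wide range. Compound 4 is estimated at 8000 nM, between 2500 nM and 25000 nM.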

Compound 4, half-maximal inhibitory concentration: 10600 nM
Beside the measured number, compound 4's estimate is 1.3-fold (0.12 log units) below it; low and high end bracket the measured number.
By their numbers in this assay, from the lowest: compounds 3, 4 and 2 (each within the scatter of the next).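

In this assay, the step to quinolin-3-yl gives a 1.0-fold higher number from compound 3 to compound 4 (0.02 log units; within the scatter) and a 1.0-fold lower number from compound 2 to compound 4 (0.02 log units; within the scatter), so compounds 2, 3 and 4 are not separated. At this aromatic carbon, the comparison now extends beyond a halogen swap on the pyridine ring to a replacement that brings in a second six-membered aromatic ring, and the number still stays within the scatter. Nothing available explains this result. From the compounds shown here alone, whether an amine or a carboxylic acid on the ring at this position would separate the compounds remains open, as does the effect of a morpholine in place of the aromatic group.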